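A few compounds are considered here, and "the series" means these few. Any claim that something is new, unique, unknown or untested is made for them only; others in the source may bear on it.

Measured compounds:
- Compound 1 `N#Cc1ccc(S(=O)(=O)[C@H]2CN(S(=O)(=O)c3ccc(Cl)cc3Cl)C[C@@]2(O)CO)cc1F` — 2 nM
- Compound 2 `N#Cc1ccc(S(=O)(=O)[C@H]2CN(S(=O)(=O)c3ccc(Cl)cc3C#N)C[C@@]2(O)CO)cc1` — 2 nM

Both compounds were tested in an assay on cells for antagonist activity at transient receptor potential cation channel subfamily V member 4 (Homo sapiens), read by FLIPR and calcium flux, with a stated time of 10 min; a lower number here means a stronger inhibitor, a higher number a weaker inhibitor. In that assay compound 1 gives 2 nM, and compound 2 gives 2 nM. The two numbers are level at the digits shown, so compound 2 stands with compound 1 within the usual scatter of the measurement, and no order between them can be read from these results.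

The next compound to be considered is compound 3 `N#Cc1ccc(S(=O)(=O)[C@H]2CN(S(=O)(=O)c3ccc(C#N)cc3Cl)C[C@@]2(O)CO)cc1`. It keeps the shared core of compound 2 and changes only the aryl group on the sulfonyl sulfur: 2-chloro-4-cyanophenyl in place of 4-chloro-2-cyanophenyl on a sulfonyl sulfur. The same atoms are present in both; only the arrangement of the chlorine and the nitrile around the ring differs.

For the measured compounds named here, no measured pair shows what such a rearrangement does here, so there is no step to lean on. The two measured compounds agree that a change at this ring left the value unchanged within the scatter, which argues for a small step at most. The step from compound 2 to compound 3 is therefore expected to be a 2.0-fold higher number from compound 2 to compound 3 (0.30 log units; within the scatter), weakening if anything. On that basis compound 3 is estimated at 4 nM, with a plausible range from 1 nM to 15 nM.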

Compound 3, half-maximal inhibitory concentration: 3.2 nM
For compound 3 the middle estimate is 1.3-fold (0.10 log units) above the measured one; low and high end bracket the measured number.
By their numbers in this assay, from the lowest: compounds 1, 2 and 3 (each within the scatter of the next).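

For the compounds shown here, compound 2 and compound 3 give the first comparison that differs in one place: 2-chloro-4-cyanophenyl in place of 4-chloro-2-cyanophenyl on a sulfonyl sulfur. In this assay the reading is a 1.6-fold higher number from compound 2 to compound 3 (0.20 log units; within the scatter), so the two compounds cannot be told apart, and in this pair, exchanging the places of the chlorine and the nitrile on the ring leaves no change that can be distinguished from the ordinary spread of repeated measurements. No supporting measurement is available that would explain this result.

This single pair speaks only for these two arrangements of the same two groups on this ring, so it cannot show how far the position tolerates other changes in general. On these data alone, it remains open whether the reading would stay in this range if an amine or a carboxylic acid took the place of the nitrile, or if a methoxy group took the place of the chlorine, since a different group could behave quite differently from a simple exchange of places.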